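This account rests on a few compounds, and the source may have more. Where it says the series, first, only, none or still open, it means among the compounds named here.

In a functional assay on MCF7 cells (Homo sapiens) for inhibition, read by MTT assay, with a stated time of 24 h (a lower number here means a stronger inhibitor of growth, a higher number a weaker inhibitor of growth), compound 1 (`COc1ccc2c(c1)c(-c1nc3ccccc3n1C(=O)c1ccccc1)cn2C`) gives 38400 nM while compound 2 (`Cn1cc(-c2nc3ccccc3n2C(=O)c2ccccc2)c2cc(Br)ccc21`) gives 50300 nM as its concentration for half-maximal growth inhibition. Among the measured compounds shown here, compound 2 therefore stands level with the only other measured compound. The move to compound 3 (`COc1ccc(C(=O)n2c(-c3cn(C)c4ccc(Br)cc34)nc3ccccc32)cc1`) is methoxy in place of hydrogen on an aromatic carbon on the benzoyl group, with methoxy in place of hydrogen on an aromatic carbon, para to a large group. For the measured compounds named here, no measured step touches this ring. Going by the values given here, the one step available, a 1.3-fold higher number from compound 1 to compound 2 (0.12 log units; within the scatter) with bromo in place of methoxy, lies elsewhere in the molecule and gives no direction for this change. No step beyond the scatter is therefore expected in this assay for this addition. The estimated step is a 1.1-fold lower number from compound 2 to compound 3 (0.05 log units; within the scatter) in this reading. For compound 3 the expected value is 45000 nM with an estimated range from 20000 nM to 100000 nM in this assay.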

Compound 3, concentration for 50% growth inhibition: 19200 nM
Beside the measured number, compound 3's estimate is 2.3-fold (0.37 log units) above it; measured number below the stated range.
By their numbers in this assay, from the lowest: compounds 3, 1 and 2 (each within the scatter of the next, the first and the last beyond it).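

Putting methoxy on the benzoyl group, para to a large group, gives a 2.6-fold lower number from compound 2 to compound 3 (0.42 log units; beyond the scatter) in this assay. This ring was untouched by the earlier step, and the change from phenyl to 4-methoxyphenyl is the first single change among these compounds to move the number beyond the scatter, so this position responds to substitution in the growth read-out. Nothing measured here explains why this addition lowers the number.

As far as these compounds go, whether this shift belongs to methoxy itself or would also follow from another group at this position, such as an amine, a carboxylic acid or a longer alkoxy chain, remains open. Also open, from the compounds shown here alone, is whether the same addition would lower the number on compound 1, as it is seen here only with the bromo group present.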